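Replacing the phenyl amide group near the assay limit

The source may report more compounds than this note shows. Statements on the series, on what has been measured and on what is new or still open speak of the compounds shown alone.

Compound 1 `CNC(=O)CCSc1ccc2c(/C=C/c3ccccn3)n[nH]c2c1` gives > 10000 nM as a limit of the assay
Compound 2 `O=C(CCSc1ccc2c(/C=C/c3ccccn3)n[nH]c2c1)Nc1cccc(Cl)c1` gives 9350 nM as a measured number
Compound 3 `CN(C)c1cccc(NC(=O)CCSc2ccc3c(/C=C/c4ccccn4)n[nH]c3c2)c1` gives > 10000 nM as a limit of the assay

In an ADME assay on BaF3 cells (Mus musculus) for antiproliferative activity, read by CCK-8 assay, with a stated time of 72 h (on this read-out higher numbers stand for weaker inhibition of growth and lower numbers for stronger inhibition of growth), compound 3 gives only a limit, > 10000 nM, and not a number. It stands at the limit of > 10000 nM in this assay, at which 2 of the 3 values shown sit.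

Compound 4 `O=C(CCSc1ccc2c(/C=C/c3ccccn3)n[nH]c2c1)Nc1ccc(Cl)c(C(F)(F)F)c1` keeps the shared core but carries 4-chloro-3-(trifluoromethyl)phenyl in place of 3-(dimethylamino)phenyl on the amide-type nitrogen: 4-chloro-3-(trifluoromethyl)phenyl in place of 3-(dimethylamino)phenyl on an amide-type nitrogen.

Within the data shown here, three measured steps bear on this change. Both an at least 1.0-fold lower number from compound 1 to compound 2 (0.02 log units; that floor lies within the scatter) and an at least 1.0-fold higher number from compound 2 to compound 3 (0.02 log units; that floor lies within the scatter) are floors within the scatter, while a step that the two limits leave unreadable from compound 1 to compound 3 gives no usable size.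

Compound 2, which also has a chloro group on its phenyl, gives 9350 nM as its number, so no step beyond the scatter is expected in this assay. The expected step is an at least 1.1-fold lower number from compound 3 to compound 4 (0.04 log units; that floor lies within the scatter).

For compound 4 the estimate is 9000 nM, with an expected range from 3500 nM to 20000 nM.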

Compound 4, concentration for 50% growth inhibition: > 10000 nM
Compound 4 ended at the assay's limit (the forecaster's own chance of this, stated with the estimate: 55%); middle value at least 1.1-fold (0.04 log units) away from the limit.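

In this assay, 4-chloro-3-(trifluoromethyl)phenyl in place of 3-chlorophenyl on the amide-type nitrogen gives an at least 1.0-fold higher number from compound 2 to compound 4 (0.02 log units; that floor lies within the scatter). The steps from compound 1 and from compound 3 to compound 4 cannot be read, since both ends of each are limits. So the larger halogen-bearing phenyl group of compound 4 does not move this series clear of the limit: the limit of > 10000 nM in this assay, at which 3 of the 4 values shown sit.

On these data alone, what a piperazine or a carboxylic acid on the phenyl ring would give here stays open. So does whether any group at this position can bring the number well below the limit.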